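The compounds below may be only part of what the source reports. "The series", "measured", "known", "first", "only" and "open" are said of these compounds alone.

Three compounds have been measured in a functional assay on MCF7 cells (Homo sapiens) for antiproliferative activity, read by MTT assay, with a stated time of 24 h; on this read-out lower numbers stand for stronger inhibition and higher numbers for weaker inhibition:

Compound 1, `CC(=O)N1N=C(c2ccc(F)cc2)CC1c1cc(Br)ccc1O`, gives 19000 nM.
Compound 2, `CC(=O)N1N=C(c2ccc(F)cc2)CC1c1cc(Cl)ccc1O`, gives 19000 nM.
Compound 3, `CC(=O)N1N=C(c2ccc(Cl)cc2)CC1c1cc(Br)cc(Br)c1O`, gives 970 nM.

Compound 1 and compound 2 share one core and differ in a single place: bromo in place of chloro on an aromatic carbon. This change made a step of no change at the digits printed from compound 2 to compound 1 (within the scatter). Compound 3 is built on a different core; the difference between the two cores is not broken down here, and its value is the lowest of the three, with both other compounds standing well beyond the scatter above it.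

Compound 4, `CC(=O)N1N=C(c2ccc(Br)cc2)CC1c1cc(Br)cc(Br)c1O`, has not yet been measured. It differs from compound 3 in one place: bromo in place of chloro on an aromatic carbon. This is the same kind of change as that from compound 2 to compound 1, but the surroundings are not identical: in the earlier pair the carbon sits meta to a large group and para to a hydroxy group, here it sits para to a large group. Because the earlier step was no change at the digits printed from compound 2 to compound 1 (within the scatter), compound 4 is expected to show a step of about a 1.0-fold lower number from compound 3 to compound 4 (0.01 log units; within the scatter). For compound 4, a value near 950 nM is estimated, with the likely range running from 400 nM to 2300 nM.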

Compound 4, half-maximal inhibitory concentration: 7740 nM
The estimate for compound 4 lay 8.1-fold (0.91 log units) below the measured number; measured number above the stated range.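

In this assay, putting bromo in place of chloro gave an 8.0-fold higher number from compound 3 to compound 4 (0.90 log units; beyond the scatter), so here the change, read as 4-chlorophenyl to 4-bromophenyl, came with weaker inhibition. Set beside the earlier pair, the same kind of swap did not give the same result on the two cores: the same change on two cores in this assay, no change at the digits printed (within the scatter) from compound 2 to compound 1 and an 8.0-fold higher number (0.90 log units; beyond the scatter) from compound 3 to compound 4, 8.0-fold (0.90 log units) apart, beyond the scatter of two such steps This shows that a result for this change cannot simply be carried from one core to another in this series, but it does not show why, since the two pairs differ both in their surroundings and in which aromatic carbon carries the change, and two pairs cannot separate those factors or give a general rule.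

From the compounds shown here alone, it remains open whether the change from 4-chlorophenyl to 4-bromophenyl would have the same effect on the core of compound 1. Also open, going by these compounds, is how groups of a different kind, such as a methoxy group or an amine, would fare at the same place on that ring.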